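Trimming Benzyloxy to Methoxy in an Aortic Relaxant Series

The compounds below may be only part of what the source reports. "The series", "measured", "known", "first", "only" and "open" are said of these compounds alone.

Three close relatives of one core have been tested in a functional assay on thoracic aorta (Rattus norvegicus, strain Wistar), with a stated time of 15 min; on this read-out lower numbers stand for an effect already at smaller amounts and higher numbers for an effect only at larger amounts of compound. Compound 1 `CC(C)Oc1ccc(Br)cc1C(C)NC(=O)N(C)S(=O)(=O)c1ccc(Cl)cc1` gives 43200 nM. Compound 2 `COc1ccc(Br)cc1C(C)NC(=O)NS(=O)(=O)c1ccc(Cl)cc1` gives 80900 nM. Compound 3 `CC(NC(=O)N(C)S(=O)(=O)c1ccc(Cl)cc1)c1cc(Br)ccc1OCc1ccccc1` gives 146000 nM, the highest of the three numbers; its gap to compound 2 lies within the scatter, whereas the step of a 3.4-fold higher number from compound 1 to compound 3 (0.53 log units; beyond the scatter) lies beyond it. Compound 4 `COc1ccc(Br)cc1C(C)NC(=O)N(C)S(=O)(=O)c1ccc(Cl)cc1` is the next candidate: hydrogen in place of phenyl on a saturated chain carbon bound to an oxygen on an aromatic ring. Among the compounds with values here, the single measured step that bears on this change is the one just named, where benzyl in place of isopropyl moved the number upward, and compound 2, which also carries methoxy, sits close to compound 1. Compound 4 is therefore expected to give 60000 nM, in the range 25000 nM to 150000 nM. The expected step is a 2.4-fold lower number from compound 3 to compound 4 (0.39 log units; beyond the scatter).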

Compound 4, half-maximal effective concentration: 19100 nM
Estimate against measurement, compound 4: 3.1-fold (0.50 log units) above; the whole stated range lies above it.
By their numbers in this assay, from the lowest: compound 4; then compounds 1, 2 and 3 (each within the scatter of the next, the first and the last beyond it).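

In this assay the trim from benzyloxy to methoxy brings a 7.6-fold lower number from compound 3 to compound 4 (0.88 log units; beyond the scatter) and the swap of isopropyl for methyl on the same oxygen brings a 2.3-fold lower number from compound 1 to compound 4 (0.35 log units; beyond the scatter) as well, so on this oxygen methyl gives the lowest number, isopropyl the next and benzyl the highest. Methyl in place of hydrogen on the amide-type nitrogen, now readable with nothing else changed, brings a 4.2-fold lower number from compound 2 to compound 4 (0.63 log units; beyond the scatter) in the same direction. Nothing available here explains why these numbers move.

Still open, as far as these compounds go, is where an ethyl group on that oxygen would fall, and whether a longer chain on the amide-type nitrogen would keep the number low.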